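This account rests on a few compounds, and the source may have more. Where it says the series, first, only, none or still open, it means among the compounds named here.

Two compounds share one core and differ only in the group on a saturated chain carbon bound to a carbonyl carbon. Compound 1 `Cn1nnnc1SCC(=O)Nc1ccc(-c2nc(-c3ccccc3)c(-c3ccccc3)n2C)cc1` carries (1-methyl-1H-tetrazol-5-yl)sulfanyl there, and in a functional assay on MCF7 cells (Homo sapiens) for cytotoxicity, read by MTT assay, with a stated time of 24 h, tested at 16 ug/mL (a higher number here means a stronger effect of the compound at the concentration tested, a lower number a weaker effect), compound 1 gives 63.7%. Compound 2 `CN1CCN(CC(=O)Nc2ccc(-c3nc(-c4ccccc4)c(-c4ccccc4)n3C)cc2)CC1` carries 4-methylpiperazin-1-yl instead, and in this assay compound 2 gives 30.1%. Going by the values given here, that single exchange brought a drop of a number 33.6 percentage points lower from compound 1 to compound 2 (beyond the scatter), so compound 2 stands lowest of the two numbers, with compound 1 as its only neighbour and well beyond the scatter above it.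

Compound 3 `Cn1c(-c2ccc(NC(=O)CN3CCN(c4ccccc4)CC3)cc2)nc(-c2ccccc2)c1-c1ccccc1` keeps the piperazine of compound 2 and changes it once: phenyl in place of methyl on an amine nitrogen in a ring. Among the compounds with values here, no measured step touches this amine nitrogen in a ring; the one step at hand, from compound 1 to compound 2, swaps the whole group on the chain carbon and shows that this region can move the read-out strongly, but it gives no direction for adding a phenyl to the ring nitrogen. The expected change in this assay is therefore small, within the scatter, in either direction, as a number 4.9 percentage points higher from compound 2 to compound 3 (within the scatter). Compound 3 is estimated at 35%, between 15% and 60%.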

Compound 3, a percentage reported as activity, at one concentration (the size of the read-out at that concentration, not a potency): 59.6%
Compound 3: middle estimate off by 24.6 percentage points, on the low side; the range from low to high includes it.
By their numbers in this assay, from the lowest: compound 2; then compounds 3 and 1 (each within the scatter of the next).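

In this assay, the amine nitrogen in the piperazine ring turns out to be a sensitive place in its own right: phenyl in place of methyl there gives a number 29.5 percentage points higher from compound 2 to compound 3 (beyond the scatter), so the read-out depends on what this nitrogen carries and not merely on the piperazine being present. The second step, a number 4.1 percentage points lower from compound 1 to compound 3 (within the scatter), shows that 4-phenylpiperazin-1-yl and (1-methyl-1H-tetrazol-5-yl)sulfanyl cannot be told apart in this read-out, which means the low number of compound 2 belongs to 4-methylpiperazin-1-yl and not to every piperazine group on this chain carbon. Nothing measured here explains why the phenyl group has this effect.

Still open, on these data alone, is whether the aromatic ring itself matters or any larger carbon group would serve, a question that a cyclohexyl or benzyl group on the same ring nitrogen could help settle. Also open, as far as these compounds go, is how a chlorine atom or a methoxy group on the phenyl ring would shift the read-out. Each number comes from a single concentration. None of them gives a potency.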